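From ethyl to cyclopropylmethoxy at the assay limit

A few compounds are considered here, and "the series" means these few. Any claim that something is new, unique, unknown or untested is made for them only; others in the source may bear on it.

Compound 2 `CCc1cc2oc(=O)n(CCC(=O)O)c2cc1Cl` gives < 10 nm/s in a physicochemical assay for permeability, using PAMPA; a higher number here means that the compound crosses the layer faster, a lower number that the compound crosses the layer more slowly. On these data alone, that reading is a limit of the assay and not a number, so the true position of compound 2 remains unknown.

Compound 1 `C[C@@H](Oc1cc2oc(=O)n(CCC(=O)O)c2cc1Cl)c1ccc(F)cn1` gives 31 nm/s in this assay. Among the measured compounds shown here, it is the only measured compound so far with a reading that is a number.

Compound 3 `O=C(O)CCn1c(=O)oc2cc(OCC3CC3)c(Cl)cc21` differs from compound 2 in one place: cyclopropylmethoxy in place of ethyl on an aromatic carbon. Cyclopropylmethoxy stands in place of ethyl on an aromatic carbon, ortho to a chloro group.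

For the measured compounds named here, no pair of measured compounds shows what a change of this kind does, so any forecast is uncertain. A modest rise in this assay, beyond the usual scatter, seems the most likely outcome, although compound 3 could also stay at the limit. This expectation leans on compound 1 at 31 nm/s, which shows that the shared core can give a measurable reading.

The expected change is an at least 2.2-fold higher number from compound 2 to compound 3 (0.34 log units; beyond the scatter), in the upward direction.

For compound 3, the estimated value is 22 nm/s, with an expected range from 10 nm/s to 50 nm/s.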

Compound 3, apparent permeability: 19 nm/s
Estimate against measurement, compound 3: 1.2-fold (0.06 log units) above, and the stated range covers the measured number.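

Cyclopropylmethoxy in place of ethyl on this aromatic carbon, ortho to a chloro group, gives a reading that is a number in this assay: compound 3 gives 19 nm/s. The change therefore amounts to an at least 1.9-fold higher number from compound 2 to compound 3 (0.27 log units; that floor lies within the scatter), so this one step cannot by itself establish a rise beyond the usual scatter. Compound 2 gives a limit and not a number, and the true size of the step stays unknown because only a floor can be stated: the limit of < 10 nm/s in this assay, at which 1 of the 3 values shown sits.

The change brings in an ether oxygen and a three-membered ring together, and the compounds shown do not separate the two, so a methoxy group or a plain propyl chain on this carbon would be the comparison still open. Equally open, on these data alone, is how an amine on this carbon would read in this assay, and whether a group of that kind would give a number at all.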